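Opening an amine ring on the shared core

The source may hold more compounds than are shown below. What is called first, only, known or untested is meant among the compounds shown, and "the series" means these compounds.

Compound 2 `Clc1cccc(-c2c[nH]c3ncnc(N4CCCCC4)c23)c1` gives 549 nM in an assay on HEK293T cells for displacement of a labelled ligand from serine/threonine-protein kinase 4 (Homo sapiens), read by NanoBRET, with a stated time of 2 h (on this read-out higher numbers stand for weaker inhibition and lower numbers for stronger inhibition), the lower of two numbers, yet within the scatter of compound 1 `OCCCNc1ncnc2[nH]cc(-c3cccc(Cl)c3)c12`, which in this assay gives 552 nM. Compound 3 `CC(CO)CN(C)c1ncnc2[nH]cc(-c3cccc(Cl)c3)c12` carries, on the same aromatic carbon, (a group of 7 heavy atoms (5 carbon, 1 nitrogen, 1 oxygen; no ring) in place of a group of 6 heavy atoms (5 carbon, 1 nitrogen; one six-membered non-aromatic ring with 1 hetero atom), on an aromatic carbon). Among the measured compounds shown here, the one step that bears on this position, a 1.0-fold lower number from compound 1 to compound 2 (0.00 log units; within the scatter), swapped a ring for an open hydroxy-bearing chain without a shift beyond the scatter, so the return to an open chain is expected to move little as well: a 1.0-fold higher number from compound 2 to compound 3 (0.01 log units; within the scatter). Compound 3 is therefore estimated at 560 nM, ranging from 250 nM to 1300 nM.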

Compound 3, half-maximal inhibitory concentration: 444 nM
Compound 3: the middle estimate sits 1.3-fold (0.10 log units) above what was measured, within the range that was stated.
By their numbers in this assay, from the lowest: compounds 3, 2 and 1 (each within the scatter of the next).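

Swapping piperidin-1-yl for the open chain gives a 1.2-fold lower number from compound 2 to compound 3 (0.09 log units; within the scatter), and enlarging the open chain of compound 1 gives a 1.2-fold lower number from compound 1 to compound 3 (0.09 log units; within the scatter), so in this assay neither change moves the number beyond the scatter. This position therefore accepts a ring, a short open chain and a larger open chain, with or without a hydrogen-bond donor, and these three compounds show no difference among them. No supporting measurement is available to explain this. Going by these compounds, it remains open whether a carboxylic acid, a primary amine or a much longer chain here would shift the number beyond the scatter.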